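The compounds below may be only part of what the source reports. "The series", "measured", "known", "first", "only" and "open" are said of these compounds alone.

Of the compounds shown here, three share one core and have been tested in a functional assay on the whole organism (strain albino) for inhibition, with Rattus norvegicus as the target, read by paw edema, with stated times of 30 min and 4 h, at a dose of 0.28 mmol/kg by the oral route; a higher number here means more inhibition at the dose given (going by the name of the read-out), a lower number less inhibition. Compound 1, `C=CCn1c(SCC(=O)Nc2ccc(C(C)=O)cc2)nnc1-c1ccc(OC)cc1`, gives 68% in this assay. Compound 2, `COc1ccc(-c2nnc(SCC(=O)Nc3ccc(C(C)=O)cc3)n2-c2ccccc2)cc1`, gives 63% in this assay. Compound 3, `COc1cc(-c2nnc(SCC(=O)Nc3ccc(C(C)=O)cc3)n2-c2ccccc2)cc(OC)c1OC`, gives 68% in this assay. Compound 4, `C=CCn1c(SCC(=O)Nc2ccc(C(C)=O)cc2)nnc1-c1cc(OC)c(OC)c(OC)c1`, has not yet been measured.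

Two single changes connect the measured compounds. The first is allyl in place of phenyl on an aromatic nitrogen, and it gave a number 5 percentage points higher from compound 2 to compound 1 (within the scatter). The second is 3,4,5-trimethoxyphenyl in place of 4-methoxyphenyl on an aromatic carbon, and it gave a number 5 percentage points higher from compound 2 to compound 3 (within the scatter). Compound 3 and compound 1 thus stand level at the digits shown, and all three numbers lie within the usual scatter of one another, so no order among them can be read from these data.

Compound 4 is reached from compound 3 by allyl in place of phenyl on an aromatic nitrogen. For the measured compounds named here, this is the same kind of change as the one from compound 2 to compound 1, but made on a different core: there the place was next to the ring atom that bears a 4-methoxyphenyl group, here it is next to the ring atom that bears a 3,4,5-trimethoxyphenyl group, the difference between the two cores being the one already described from compound 2 to compound 3.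

Because the earlier step of this kind gave a number 5 percentage points higher from compound 2 to compound 1 (within the scatter), the step from compound 3 to compound 4 is expected to be about a number 4 percentage points higher from compound 3 to compound 4 (within the scatter) in this assay. Compound 4 is therefore estimated at 72% in this assay, most likely between 58% and 84%.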

Compound 4, a percentage reported as inhibition, in the whole organism at one dose (the size of the read-out at that dose, not a potency): 68%
For compound 4 the middle estimate is 4 percentage points above the measured one; the measured number falls inside the stated range.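

Putting allyl in place of phenyl on the aromatic nitrogen gives no change at the digits printed from compound 3 to compound 4 (within the scatter) in this assay. Set beside the earlier case, the same change reads alike on the two cores, as far as this assay can tell: the same change on two cores in this assay, a number 5 percentage points higher (within the scatter) from compound 2 to compound 1 and no change at the digits printed (within the scatter) from compound 3 to compound 4, 5 percentage points apart, within the scatter of two such steps. So nothing here speaks against carrying this swap from the 4-methoxyphenyl core to the 3,4,5-trimethoxyphenyl core, but since both steps lie within the scatter, the pair does not show that the swap has a real effect on either core, or that the two cores respond to it in exactly the same way, and a reading at a single dose is a size of effect, not a potency.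

The compounds shown leave open whether a different group on that nitrogen, such as a methyl, a longer chain or a chain ending in an amine, would move the number beyond the scatter. They also leave open what a carboxylic acid or a nitrile would do in place of the acetyl group on the shared core, a part of the molecule that stays the same in all four compounds.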